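The compounds below may be only part of what the source reports. "The series", "measured", "known", "first", "only" and "open" are said of these compounds alone.

Measured compounds:
- Compound 1 `Cn1c(/C=C/C(=O)c2ccc(O)cc2O)cc(Br)c1Br` gives 12000 nM in a functional assay on KB403 cells (Homo sapiens) for cytotoxicity, read by MTT assay, with stated times of 6 h and 48 h; on this read-out higher numbers stand for weaker inhibition and lower numbers for stronger inhibition.
- Compound 2 `Cn1c(/C=C/C(=O)c2ccc(O)cc2)cc(Br)c1Br` gives >= 100000 nM in this assay, which is a limit of the assay and not a number.
- Compound 3 `O=C(/C=C/c1cc(Br)c(Br)[nH]1)c1ccccc1O` gives >= 100000 nM in this assay, again a limit of the assay and not a number.

The difference between the core of compound 1 and the core of compound 3 is not broken down here. What is broken down is the change from compound 1 to compound 2, namely (hydrogen in place of hydroxy on an aromatic carbon). As far as these compounds go, that change produced an at least 8.3-fold higher number from compound 1 to compound 2 (0.92 log units; beyond the scatter), a step that rests on (the limit of >= 100000 nM in this assay, at which 2 of the 3 values shown sit), so its full size is unknown.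

Compound 4 `O=C(/C=C/c1cc(Br)c(Br)[nH]1)c1ccccc1` is the untested partner of compound 3. The change from compound 3 to compound 4 is hydrogen in place of hydroxy on an aromatic carbon. Among the compounds with values here, it is the same kind of change as the one from compound 1 to compound 2, though not the same: in compound 1 the hydroxy that leaves sits meta to a hydroxy group, whereas in compound 3 no such group is present around the place.

Since compound 3 already sits at the limit, and the earlier change gave an at least 8.3-fold higher number from compound 1 to compound 2 (0.92 log units; beyond the scatter), compound 4 is expected to show a step that the limit leaves unreadable from compound 3 to compound 4 and most likely to return another limit. In this assay compound 4 is thus estimated at 150000 nM, within 50000 nM to 500000 nM.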

Compound 4, half-maximal inhibitory concentration: >= 100000 nM
Compound 4: a limit, no number (the forecaster's own chance of this, stated with the estimate: 85%); the middle value is on the limit's open side.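

No step can be read between compound 3 and compound 4, because both values are limits of the assay and not numbers: the limit of >= 100000 nM in this assay, at which 3 of the 4 values shown sit.

The compounds shown leave open how far compound 2, compound 3 and compound 4 lie past that limit, and whether hydrogen in place of hydroxy matters on the core of compound 3 as it does on the core of compound 1.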